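Removing an Ethoxy Group from Compound 1

A few compounds are considered here, and "the series" means these few. Any claim that something is new, unique, unknown or untested is made for them only; others in the source may bear on it.

Compound 1 `CCOc1ccc2nc(Cl)c(/C=N/NC(=O)c3cc4cc(Br)ccc4oc3=O)cc2c1` gives 17000 nM in a functional assay on PANC-1 cells (Homo sapiens) for antiproliferative activity, read by fluorescence and resazurin assay, with a stated time of 48 h; a higher number here means a weaker inhibitor, a lower number a stronger inhibitor.
Compound 2 `O=C(N/N=C/c1cccnc1)c1cc2cc(Br)ccc2oc1=O` gives 8350 nM in this assay.
Compound 3 `CCOc1ccc(NC(=O)c2cc3cc([N+](=O)[O-])ccc3oc2=O)cc1` gives 12100 nM in this assay.

For the measured compounds named here, of these three numbers, the one for compound 1 is the highest. Its gap to compound 3 falls within the usual scatter of repeated measurements, so the two cannot be told apart; only the gap to compound 2 lies beyond that scatter, with compound 2 showing the lower number.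

Compound 4 `O=C(N/N=C/c1cc2ccccc2nc1Cl)c1cc2cc(Br)ccc2oc1=O` has not yet been measured in this assay. It differs from compound 1 in one place: hydrogen in place of ethoxy on an aromatic carbon. Going by the values given here, no pair of measured compounds differs by this change alone, so there is no measured step to show how large such a change tends to be here. The expected step is a 1.4-fold lower number from compound 1 to compound 4 (0.15 log units; within the scatter), a change no larger than the scatter and slightly toward a lower number. Compound 4 is therefore estimated at 12000 nM, with a range from 5000 nM to 35000 nM.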

Compound 4, half-maximal inhibitory concentration: 5450 nM
Compound 4: middle estimate off by 2.2-fold (0.34 log units), on the high side; the range from low to high includes it.
By their numbers in this assay, from the lowest: compounds 4, 2, 3 and 1 (each within the scatter of the next, the first and the last beyond it).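

In this assay, for the compounds shown here, replacing ethoxy with hydrogen on the six-membered aromatic ring of carbon only gives a modest step that lies beyond the scatter (a 3.1-fold lower number from compound 1 to compound 4 (0.49 log units; beyond the scatter)), and this is the first measured step here that comes from a single change. It shows that this position is not indifferent to what it carries, and that the ethoxy group is not needed there for activity in this cell assay, since the number falls once the group is gone. No measurement shown here accounts for this step.

Going by these compounds, it remains open whether methoxy, a longer chain such as butoxy, or an amine at this position would give a number closer to compound 4 or to compound 1. On these data alone, this step also rests on a single pair of compounds, so whether the same change would shift the number in a similar way on another core remains unknown.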